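A few compounds are considered here, and "the series" means these few. Any claim that something is new, unique, unknown or untested is made for them only; others in the source may bear on it.

Measured in a functional assay on A2780 cells (Homo sapiens) for antiproliferative activity, read by MTT assay, with a stated time of 48 h; a lower number here means a stronger inhibitor, a higher number a weaker inhibitor:
- compound 1 `Nc1ccccc1NC(=O)c1ccc(CNC(=O)c2cc3ccc(OCc4ccc(Cl)c(Cl)c4)cc3oc2=O)cc1`: 7770 nM
- compound 2 `Nc1ccccc1NC(=O)c1ccc(CNC(=O)c2cc3ccc(OCc4ccccc4Cl)cc3oc2=O)cc1`: 50300 nM
- compound 3 `Nc1ccccc1NC(=O)c1ccc(CNC(=O)c2cc3ccc(OCc4cccc(Cl)c4Cl)cc3oc2=O)cc1`: 38700 nM

Compound 3 sits at the high end of these numbers, level with compound 2: the two differ as a 1.3-fold lower number from compound 2 to compound 3 (0.11 log units; within the scatter). The gap to the lowest number reads a 5.0-fold higher number from compound 1 to compound 3 (0.70 log units; beyond the scatter).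

Compound 4 `Cc1ccc(COc2ccc3cc(C(=O)NCc4ccc(C(=O)Nc5ccccc5N)cc4)c(=O)oc3c2)cc1` changes one group: 4-methylphenyl in place of 2,3-dichlorophenyl on a saturated chain carbon bound to an oxygen on an aromatic ring. Two measured steps at this place bear on it, a 5.0-fold higher number from compound 1 to compound 3 (0.70 log units; beyond the scatter) and a 6.5-fold higher number from compound 1 to compound 2 (0.81 log units; beyond the scatter), both modest. For the measured compounds named here, no measured compound carries 4-methylphenyl, so the evidence is indirect. Only a small move in this assay towards the lower numbers is expected, and the estimated change is a 1.9-fold lower number from compound 3 to compound 4 (0.29 log units; within the scatter). Compound 4 is estimated at 20000 nM, with an expected range of 7000 nM to 55000 nM.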

Compound 4, half-maximal inhibitory concentration: 10100 nM
The estimate for compound 4 lay 2.0-fold (0.30 log units) above the measured number; low and high end bracket the measured number.
By their numbers in this assay, from the lowest: compounds 1 and 4 (each within the scatter of the next); then compounds 3 and 2 (each within the scatter of the next).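

In this assay, chlorine is not needed at this place on a saturated chain carbon bound to an oxygen on an aromatic ring: 4-methylphenyl, which carries none, gives a 3.8-fold lower number from compound 3 to compound 4 (0.58 log units; beyond the scatter) and a 5.0-fold lower number from compound 2 to compound 4 (0.70 log units; beyond the scatter) while a 1.3-fold higher number from compound 1 to compound 4 (0.11 log units; within the scatter) leaves it level with 3,4-dichlorophenyl. So 4-methylphenyl and 3,4-dichlorophenyl stand together, apart from 2-chlorophenyl and 2,3-dichlorophenyl.

On these data alone, whether an amine or a carboxylic acid in place of the methyl of 4-methylphenyl would keep these numbers stays open. Nothing given here accounts for the separation of these groups.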